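From bromo to hydroxy on the benzyl group

The source may hold more compounds than are shown below. What is called first, only, known or untested is meant among the compounds shown, and "the series" means these compounds.

Compound 1 `CN(C)c1ccc(NC(=O)c2cc(Cl)ccc2O)c(Cl)c1`: 85100 nM
Compound 2 `O=C(Nc1ccc(NCc2ccc(Br)cc2)cc1Cl)c1cc(Cl)ccc1O`: 40900 nM

In an ADME assay on A549 cells (Homo sapiens) for cytotoxicity, read by resazurin assay, with a stated time of 48 h (a lower number here means that less compound is tolerated, a higher number that more compound is tolerated), compound 2 gives 40900 nM, the lower of the two measured numbers. Compound 3 `O=C(Nc1ccc(NCc2ccc(O)cc2)cc1Cl)c1cc(Cl)ccc1O` has hydroxy in place of bromo on an aromatic carbon. For the measured compounds named here, only one measured step bears on this change: a 2.1-fold lower number from compound 1 to compound 2 (0.32 log units; beyond the scatter), the modest step that brought in (4-bromobenzyl)amino. Going by the values given here, no measured compound carries hydroxy there, so a step no larger than that one is expected in this assay, towards a higher number. The expected change is a 1.5-fold higher number from compound 2 to compound 3 (0.17 log units; within the scatter). For compound 3 the estimated value is 60000 nM, with an expected range of 24000 nM to 130000 nM.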

Compound 3, half-maximal cytotoxic concentration: 116000 nM
The estimate for compound 3 lay 1.9-fold (0.29 log units) below the measured number; measured number inside the range.
By their numbers in this assay, from the lowest: compound 2; then compounds 1 and 3 (each within the scatter of the next).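

In this assay the change from 4-bromobenzyl to 4-hydroxybenzyl gives a 2.8-fold higher number from compound 2 to compound 3 (0.45 log units; beyond the scatter) and so shows that the group on this aromatic carbon alone can move the number beyond the scatter. The lower number of compound 2 thus goes with the bromo and not with the benzylamino arm as such: with (4-hydroxybenzyl)amino in place of dimethylamino, the comparison reads a 1.4-fold higher number from compound 1 to compound 3 (0.13 log units; within the scatter) and places compound 3 within the scatter of compound 1. Going by these compounds, whether chloro, methoxy or an amine at this place would side with bromo or with hydroxy remains open. Nothing available explains the step between bromo and hydroxy.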